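The source may report more compounds than this note shows. Statements on the series, on what has been measured and on what is new or still open speak of the compounds shown alone.

Of the compounds shown here, three sharing one core have been measured in a physicochemical assay for solubility, read by HPLC, with a stated time of 24 h; a lower number here means a less soluble compound, a higher number a more soluble compound. Compound 1 `O=C(OC[C@H]1CN(c2ccc(-n3cc(-c4ccccn4)cn3)c(F)c2)C(=O)O1)c1ccccc1` gives only a limit in this assay, <= 65400 nM. Compound 2 `O=C1O[C@@H](Cn2ccnn2)CN1c1ccc(-n2cc(-c3ccccn3)cn2)c(F)c1` gives 247000 nM. Compound 3 `COC(=O)NC[C@H]1CN(c2ccc(-n3cc(-c4ccccn4)cn3)c(F)c2)C(=O)O1` gives 34100 nM, the lowest of the two plain numbers, as seen in a 7.2-fold lower number from compound 2 to compound 3 (0.86 log units; beyond the scatter). The step of an at least 3.7-fold higher number from compound 1 to compound 2 (0.57 log units; beyond the scatter) runs the other way, and a step that the limit leaves unreadable from compound 1 to compound 3 cannot be read.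

Compound 4 `O=C1O[C@@H](CNC(=O)C(F)(F)F)CN1c1ccc(-n2cc(-c3ccccn3)cn2)c(F)c1` differs from compound 3 by trifluoromethyl in place of methoxy on a carbonyl carbon. No measured step exchanges a group on a carbonyl carbon; the shown steps swap the whole side group on the chain, so none bears closely on this change. Compound 4 is therefore expected to shift by a 1.6-fold lower number from compound 3 to compound 4 (0.19 log units; within the scatter), a step kept within the scatter. Compound 4 is estimated at 22000 nM, between 7000 nM and 65000 nM.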

Compound 4, solubility: 114000 nM
Compound 4: the middle estimate sits 5.2-fold (0.71 log units) below what was measured, and the stated range ends below it.
By their numbers in this assay, from the lowest: compound 3; then compound 4; then compound 2.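

In this assay, within the data shown here, a change confined to the group on the carbonyl carbon is enough to move the number: a 3.3-fold higher number from compound 3 to compound 4 (0.52 log units; beyond the scatter), whereas the earlier steps swapped the whole side group. Compound 2 still keeps the highest number, shown by a 2.2-fold lower number from compound 2 to compound 4 (0.34 log units; beyond the scatter). Only a floor can be read for an at least 1.7-fold higher number from compound 1 to compound 4 (0.24 log units; that floor lies within the scatter), and the value behind it is a limit: the limit of <= 65400 nM in this assay, at which 1 of the 4 values shown sits.

This is a single pair, so it sets one group against one other. From the compounds shown here alone, whether a plain methyl or an amine on this carbonyl carbon would give a number closer to methoxy or to trifluoromethyl stays open.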